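Propyl to cyclobutyl on the ring amine of compound 1

A few compounds are considered here, and "the series" means these few. Any claim that something is new, unique, unknown or untested is made for them only; others in the source may bear on it.

Among the compounds with values here, compound 1 `CCCNc1nc(-c2ccccc2)nc2c1nnn2Cc1ccccc1` is the only member of this series with a number in an assay on Cerebral cortex for displacement of a labelled ligand from adenosine receptor A1 (Bos taurus); on this read-out higher numbers stand for weaker inhibition and lower numbers for stronger inhibition: compound 1 gives 37 nM. Compound 2 `CCCNc1nc(-c2ccccc2)nc2c1nnn2Cc1ccccc1C(F)(F)F`, which carries a trifluoromethyl group on the benzyl ring, has no result in this assay; for compound 2 the entry reads "not determined" (no result reported), so it offers no comparison.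

The next compound, compound 3 `c1ccc(Cn2nnc3c(NC4CCC4)nc(-c4ccccc4)nc32)cc1`, differs from compound 1 in one place: cyclobutyl in place of propyl on a nitrogen on an aromatic ring. The propylamino becomes cyclobutylamino, a ring of four carbon atoms replacing a chain of three.

Within the data shown here, no measured pair with this change is available, so no step can guide the direction. The change is small in size, and the expectation is a step of no more than the usual scatter, if anything toward stronger inhibition. The step expected from compound 1 to compound 3 in this assay is a 1.5-fold lower number from compound 1 to compound 3 (0.17 log units; within the scatter). For compound 3 the estimated value in this assay is 25 nM, with a likely range from 8 nM to 80 nM.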

Compound 3, inhibition constant: 5 nM
Compound 3: middle estimate off by 5.0-fold (0.70 log units), on the high side, outside the stated range (below it).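

Cyclobutyl in place of propyl on a nitrogen on an aromatic ring gives a 7.4-fold lower number from compound 1 to compound 3 (0.87 log units; beyond the scatter) in this assay, and this is the first step the series offers. Until now, the series held a single number and no comparison, whereas this pair shows that the group on this nitrogen moves the read-out and that a four-membered ring of carbon only is accepted there, with stronger inhibition than the propyl chain gives on the same core. No measurement at hand accounts for the step, which rests on one pair alone.

Going by these compounds, whether the gain belongs to the ring as such or to the larger group stays open, and cyclopropyl, cyclopentyl, cyclohexyl or an open butyl chain on the same nitrogen would separate the two readings. Also open, on these data alone, is whether the gain carries over to other groups on the benzyl ring, such as the trifluoromethyl of compound 2, or to a polar group on the cyclobutyl ring, such as a hydroxyl or an amine.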